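A Chloro-to-Cyano Swap Carried onto a Second Core

The compounds below may be only part of what the source reports. "The series", "measured", "known", "first", "only" and "open" are said of these compounds alone.

Compound 1 `CCS(=O)(=O)Nc1ccc(NC(=O)c2ccc(Cl)cc2)cc1OC` and compound 2 `CCS(=O)(=O)Nc1ccc(NC(=O)c2ccc(C#N)cc2)cc1OC` share one core and differ in a single place: cyano in place of chloro on an aromatic carbon. In an ADME assay on RAW264.7 cells (Mus musculus) for cytotoxicity, read by MTT assay, with a stated time of 48 h (on this read-out lower numbers stand for stronger inhibition and higher numbers for weaker inhibition), compound 1 gives 60100 nM, and compound 2 gives 66400 nM. Between them the data show the step of a 1.1-fold higher number from compound 1 to compound 2 (0.04 log units; within the scatter).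

Compound 3 `O=C(Nc1ccc(NS(=O)(=O)C(F)(F)F)c(Cl)c1)c1ccc(Cl)cc1` is built on another core; how that core differs from the core of compound 1 is not broken down here. In this assay compound 3 gives 47200 nM, a number that lies within the scatter of those for compound 1 and compound 2.

Compound 4 `N#Cc1ccc(C(=O)Nc2ccc(NS(=O)(=O)C(F)(F)F)c(Cl)c2)cc1` has not yet been measured. It arises from compound 3 by the following change: cyano in place of chloro on an aromatic carbon. The place of the change reads the same for both pairs, so it is the same change as that from compound 1 to compound 2. The step in this assay is expected to be a 1.1-fold higher number from compound 3 to compound 4 (0.04 log units; within the scatter). This expectation rests on the step of a 1.1-fold higher number from compound 1 to compound 2 (0.04 log units; within the scatter). The estimate for compound 4 in this assay is 52000 nM, expected to fall between 25000 nM and 105000 nM.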

Compound 4, half-maximal inhibitory concentration: > 250000 nM
Compound 4: a limit, no number; the forecaster's own chance of this, stated with the estimate: 10%; middle value at least 4.8-fold (0.68 log units) away from the limit.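

In this assay compound 4 stands at > 250000 nM, a limit of the assay and not a number: the limit of > 250000 nM in this assay, at which 1 of the 4 values shown sits. On the core of compound 3, cyano in place of chloro gives an at least 5.2-fold higher number from compound 3 to compound 4 (0.72 log units; beyond the scatter), so the step seen on the core of compound 1 did not carry over to this core: the same change on two cores in this assay, a 1.1-fold higher number (0.04 log units; within the scatter) from compound 1 to compound 2 and an at least 5.2-fold higher number (0.72 log units; beyond the scatter) from compound 3 to compound 4, at least 4.7-fold (0.68 log units) apart, beyond the scatter of two such steps. The true size of the new step stays unknown past that limit, and a single pair on each core neither gives a cause for the difference nor sets a rule for any further core.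

The compounds shown leave open which part of the core of compound 3 goes with the larger step. They also leave open whether an amine or a carboxylic acid in the place of the cyano on that core would reach the same limit. Compound 3 gives 47200 nM, and whether such a group would stay close to that value is open as well.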